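The compounds below may be only part of what the source reports. "The series", "measured", "known", "first", "only" and "open" are said of these compounds alone.

Within the data shown here, compound 2 `C/C(=N\NC(=O)/C(C#N)=C/c1ccc(N(C)C)cc1)c1c(O)c2ccc(O)cc2oc1=O` gives 4310 nM in a functional assay on A549 cells (Homo sapiens) for cytotoxicity, read by MTT assay, with a stated time of 24 h (on this read-out lower numbers stand for stronger inhibition and higher numbers for weaker inhibition), and holds the lower of the two numbers measured so far, yet its gap to compound 1 `C/C(=N\NC(=O)/C(C#N)=C/c1ccc(O)cc1)c1c(O)c2ccc(O)cc2oc1=O`, which gives 6230 nM, is within the scatter. Compound 3 `C/C(=N\NC(=O)/C(C#N)=C/c1ccccc1[N+](=O)[O-])c1c(O)c2ccc(O)cc2oc1=O` differs from compound 2 by 2-nitrophenyl in place of 4-(dimethylamino)phenyl on a double-bonded chain carbon bound to a double-bonded chain carbon. Among the measured compounds shown here, the only measured step touching this part of the molecule, a 1.4-fold lower number from compound 1 to compound 2 (0.16 log units; within the scatter), stayed within the scatter, so no shift beyond the scatter is expected for compound 3 in this assay. Compound 3 is estimated at 5000 nM, with a range of 2000 nM to 15000 nM, meaning a 1.2-fold higher number from compound 2 to compound 3 (0.06 log units; within the scatter).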

Compound 3, half-maximal inhibitory concentration: 11400 nM
Beside the measured number, compound 3's estimate is 2.3-fold (0.36 log units) below it; low and high end bracket the measured number.
By their numbers in this assay, from the lowest: compounds 2, 1 and 3 (each within the scatter of the next, the first and the last beyond it).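

In this assay this place on the double-bonded chain carbon now shows a step beyond the scatter: a 2.6-fold higher number from compound 2 to compound 3 (0.42 log units; beyond the scatter) when 2-nitrophenyl replaces 4-(dimethylamino)phenyl. Set against 4-hydroxyphenyl, the same 2-nitrophenyl gives a 1.8-fold higher number from compound 1 to compound 3 (0.26 log units; within the scatter) and stays within the scatter, so only the two ends of this short series separate. Nothing available here gives a reason for this shift. Still open, from the compounds shown here alone, is how a plain phenyl or a 4-nitrophenyl would read at this place, which would help tell the nitro group itself from where it sits on the ring.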